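A few compounds are considered here, and "the series" means these few. Any claim that something is new, unique, unknown or untested is made for them only; others in the source may bear on it.

Compound 1 `Cc1ccc(-c2nn(-c3ccccc3)c(/N=C/N(C)C)c2C=O)cc1`: 9500 nM
Compound 2 `CN(C)/C=N/c1c(C=O)c(C(C)(C)C)nn1-c1ccccc1`: 43500 nM
Compound 3 `CN/C=N/c1cc(-c2ccccc2)nn1-c1ccccc1`: > 50000 nM

These three results come from a functional assay on Jurkat cells (Homo sapiens) for inhibition, read by MTT assay, with a stated time of 72 h; on this read-out higher numbers stand for weaker inhibition of growth and lower numbers for stronger inhibition of growth. Among the compounds with values here, compound 1 and compound 2 give plain numbers, and the only step between measured compounds that differ in one place is a 4.6-fold higher number from compound 1 to compound 2 (0.66 log units; beyond the scatter). Within the data shown here, compound 3 stands apart: in this assay compound 3 gives > 50000 nM, which is a limit rather than a number, the one value that sits at the limit of > 50000 nM in this assay, at which 1 of the 3 values shown sits.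

Compound 4 `CN/C(C)=N/c1cc(-c2ccccc2)nn1-c1ccccc1` differs from compound 3 in one place: a group of 5 heavy atoms (3 carbon, 2 nitrogen; no ring) in place of a group of 4 heavy atoms (2 carbon, 2 nitrogen; no ring), on an aromatic carbon. Among the measured compounds shown here, no measured step involves a change of this kind. The step from compound 1 to compound 2 exchanges a group of quite another sort, and the two measured compounds with their own structures do not share this chain, so the measured data say nothing about how lengthening this chain on the shared core of compound 3 would move the result in this assay. Compound 3 gives only a limit, so there is no number to move from.

Compound 4 is therefore expected to give a result much like that of compound 3, estimated at 60000 nM with a range from 20000 nM to 200000 nM, which as a step means an expected step that the limit leaves unreadable from compound 3 to compound 4, most probably reported once more only as a limit.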

Compound 4, concentration for 50% growth inhibition: > 50000 nM
Compound 4: a limit, no number; the forecaster's own chance of this, stated with the estimate: 75%; the middle value is on the limit's open side.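

In this assay compound 4 gives > 50000 nM, which is a limit and not a number. Compound 3 gives > 50000 nM, also a limit. No step from compound 3 to compound 4 can be read, as both results sit at one ceiling: the limit of > 50000 nM in this assay, at which 2 of the 4 values shown sit.

The compounds shown leave open whether exchanging these two chains changes growth inhibition at all.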